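The source may report more compounds than this note shows. Statements on the series, on what has been measured and on what is new or still open speak of the compounds shown alone.

Notes on the series. Compound 1 `C[Se]/C(=N\C(=O)c1cc2ccccc2s1)NC(=O)c1cc2ccccc2s1` carries a methylselanyl group on the carbon with a double bond to nitrogen; in a functional assay on MCF7 cells (Homo sapiens) for cytotoxicity, read by MTT assay, with a stated time of 72 h (a higher number here means that more compound is tolerated, a lower number that less compound is tolerated), compound 1 gives 80600 nM. Compound 3 `CS/C(=N\C(=O)c1cc2ccccc2s1)NC(=O)c1cc2ccccc2s1` is the sulfur counterpart; in this assay compound 3 gives 78500 nM, the lowest of the two plain numbers, with compound 1 as its nearest neighbour. The exchange a 1.0-fold lower number from compound 1 to compound 3 (0.01 log units; within the scatter) is within the scatter. Compound 2 `CS/C(=N\C(=O)c1csc([N+](=O)[O-])c1)NC(=O)c1csc([N+](=O)[O-])c1`, which carries nitro-substituted thiophenes instead of the benzothiophenes, reaches only a limit of this assay: compound 2 gives > 100000 nM. That limit is the point (the limit of > 100000 nM in this assay, at which 1 of the 3 values shown sits).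

Compound 4 `O=C(/N=C(/NC(=O)c1cc2ccccc2s1)[Se]Cc1ccccc1)c1cc2ccccc2s1` is not yet measured. Relative to compound 3 the change is a group of 8 heavy atoms (7 carbon, 1 selenium; one six-membered aromatic ring of carbon only) in place of a group of 2 heavy atoms (1 carbon, 1 sulfur; no ring), on a carbon with a double bond to nitrogen. Among the measured compounds shown here, the only measured step touching this position is the selenium-for-sulfur swap from compound 1 to compound 3, which left the number where it was. For the measured compounds named here, no measured pair speaks to the benzyl part entering here. On that basis the step to compound 4 is expected to stay near the scatter, with no direction favoured: for compound 4 the estimate is 70000 nM, between 25000 nM and 150000 nM. In step terms the expectation from compound 3 is a 1.1-fold lower number from compound 3 to compound 4 (0.05 log units; within the scatter).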

Compound 4, concentration lethal to 50% of the cells: 87900 nM
Beside the measured number, compound 4's estimate is 1.3-fold (0.10 log units) below it; measured number inside the range.
By their numbers in this assay, from the lowest: compounds 3, 1 and 4 (each within the scatter of the next). At a limit, above all of these: compound 2.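

In this assay, the measured step of a 1.1-fold higher number from compound 3 to compound 4 (0.05 log units; within the scatter) shows that a much larger group, with 8 heavy atoms including selenium and one six-membered aromatic ring, can replace methylsulfanyl on the carbon with a double bond to nitrogen without a change beyond the scatter. The step of a 1.1-fold higher number from compound 1 to compound 4 (0.04 log units; within the scatter) isolates phenyl in place of hydrogen on the saturated chain carbon bound to a selenium atom, which the earlier selenium-for-sulfur pair could not address, and it too stays within the scatter. Compounds 1, 3 and 4 therefore cannot be told apart at this position, and nothing measured here gives a reason for that.

From the compounds shown here alone, whether an amine or a carboxylic acid on the benzyl ring, or a longer chain on the selenium, would shift the number remains open. Among the compounds shown here, for compound 2, > 100000 nM is a limit of the assay and not a number, so it gives no step to set against the others.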